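The source may hold more compounds than are shown below. What is called first, only, known or untested is meant among the compounds shown, and "the series" means these compounds.

Measured compounds in a functional assay on NCI60 cells (Homo sapiens) for cytotoxicity; a higher number here means a weaker inhibitor of growth, a lower number a stronger inhibitor of growth:
- compound 1 `Cc1ccc2c(n1)C(=O)C=C(N1CC1)C2=O` gives 2040 nM
- compound 2 `COCCCNC1=CC(=O)c2nc(-c3ccccc3)ccc2C1=O` gives 19100 nM
- compound 3 `COc1cc(CNC2=CC(=O)c3nc(-c4ccccc4)ccc3C2=O)cc(OC)c1OC` gives 15500 nM

Of these three, compound 2 has the highest number, meaning the weakest growth inhibition. Compound 3 sits close beside it, within the scatter of repeated measurements, so no order can be read between those two. Compound 1, with a different shape of side chain on the shared core, stands well below compound 2, beyond the scatter.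

The unmeasured compound 4 `O=C1C(NCc2ccccc2)=CC(=O)c2nc(-c3ccccc3)ccc21` differs from compound 2 in one place: phenyl in place of 2-methoxyethyl on a saturated chain carbon bound to an amine nitrogen. Among the compounds with values here, there is no measured pair that shows this exact change, so its effect cannot be read off directly. What can be said is that compound 3, which also carries an aromatic ring on the carbon bound to the amine nitrogen, gives 15500 nM, a number indistinguishable from compound 2. On that basis the step of a 1.4-fold lower number from compound 2 to compound 4 (0.13 log units; within the scatter) is expected to stay within the scatter, in no clear direction. Compound 4 is therefore estimated at 14000 nM, with a range from 5000 nM to 40000 nM.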

Compound 4, concentration for total growth inhibition: 15500 nM
For compound 4 the middle estimate is 1.1-fold (0.04 log units) below the measured one; low and high end bracket the measured number.
By their numbers in this assay, from the lowest: compound 1; then compounds 3, 4 and 2 (each within the scatter of the next).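

In this assay, within the data shown here, exchanging the 3-methoxypropyl chain for benzyl gives a 1.2-fold lower number from compound 2 to compound 4 (0.09 log units; within the scatter), the first direct reading of this change at this position. An open chain with an ether oxygen and a group carrying a six-membered aromatic ring therefore cannot be told apart here, on a saturated chain carbon bound to an amine nitrogen. Nothing measured speaks to why these two groups read alike.

The compounds shown leave open whether any other group at this place would shift growth inhibition beyond the scatter, such as a chain ending in a dimethylamino group, a carboxylic acid, or a single methyl. They also leave open whether the same exchange would read alike on a different core.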